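Methyl in place of methoxy: working notes on the series

The source may report more compounds than this note shows. Statements on the series, on what has been measured and on what is new or still open speak of the compounds shown alone.

Measured in a functional assay on MCF7 cells (Homo sapiens) for antiproliferative activity, read by MTT assay, with a stated time of 48 h; a higher number here means a weaker inhibitor, a lower number a stronger inhibitor:
- compound 1 `Cc1ccc(/C=C/C(=O)Nc2nnc(-c3ccc(Cl)cc3)s2)cc1`: 1.44 ug/mL
- compound 2 `COc1ccc(-c2nnc(NC(=O)/C=C/c3ccc(C)cc3)s2)cc1`: 0.31 ug/mL

Of these two, compound 2 has the lower number at 0.31 ug/mL, so it is the stronger inhibitor of the pair, and the gap lies beyond the scatter.

The next compound to be read is compound 3 `Cc1ccc(/C=C/C(=O)Nc2nnc(-c3ccc(C)cc3)s2)cc1`. It differs from compound 2 in one place: methyl in place of methoxy on an aromatic carbon. This is methyl in place of methoxy on an aromatic carbon, para to a large group, or 4-methoxyphenyl to 4-methylphenyl.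

For the measured compounds named here, only one measured step bears on this change: a 4.6-fold lower number from compound 1 to compound 2 (0.67 log units; beyond the scatter), a modest step beyond the scatter, with methoxy in place of chloro on an aromatic carbon. No methyl partner has been measured at this place, so that step gives direction only loosely. On the strength of that step, part of it is expected to be lost when methoxy leaves, and the expected change is toward a higher number in this assay, smaller than the measured step and possibly close to the scatter. The estimated step is a 2.4-fold higher number from compound 2 to compound 3 (0.38 log units; beyond the scatter).

For compound 3 the estimated value is 0.75 ug/mL, with an expected range from 0.3 ug/mL to 1.9 ug/mL.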

Compound 3, half-maximal inhibitory concentration: 0.61 ug/mL
Compound 3: the middle estimate sits 1.2-fold (0.09 log units) above what was measured; the measured number falls inside the stated range.
By their numbers in this assay, from the lowest: compounds 2 and 3 (each within the scatter of the next); then compound 1.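

In this assay, the methoxy of compound 2 and the methyl of compound 3 cannot be told apart, with a 2.0-fold higher number from compound 2 to compound 3 (0.29 log units; within the scatter), so the step away from chloro is no longer tied to methoxy alone. Methyl also stands clear of chloro at this place, with a 2.4-fold lower number from compound 1 to compound 3 (0.37 log units; beyond the scatter), and compound 1 now has a higher number than both of the others by more than the scatter; at this position on the aromatic ring, the series therefore divides into chloro on one side and methoxy and methyl together on the other. Moving from methoxy to methyl removes an oxygen and the one hydrogen-bond acceptor counted for it without a change beyond the scatter, but no measured property is available to explain this result or the separation of chloro from the other two groups.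

The compounds shown leave open whether an amine, a hydroxyl group or a carboxylic acid at this place would read with methoxy and methyl or with chloro. They also leave open how a longer chain, such as ethoxy or propyl, would read here, and whether the division seen with these three groups would persist with any of them.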